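Moving the fluorine on a boron-bearing chalcone

The source may report more compounds than this note shows. Statements on the series, on what has been measured and on what is new or still open speak of the compounds shown alone.

Compound 3 `O=C(/C=C/c1ccc2c(c1)B(O)OC2)c1ccccc1F` has the lowest of the two numbers shown in a toxicity assay on WI-38 cells (Homo sapiens) for cytotoxicity, read by MTT assay, with a stated time of 48 h (a higher number here means a weaker inhibitor, a lower number a stronger inhibitor), although its nearest neighbour, compound 2 `Nc1ccc(C(=O)/C=C/c2ccc3c(c2)B(O)OC3)cc1`, sits within the scatter: compound 3 gives 23600 nM and compound 2 gives 25400 nM. Compound 1 `O=C(/C=C/c1ccc2c(c1)B(O)OC2)c1ccc(O)cc1` reaches only a limit of this assay, > 100000 nM; that is the limit of > 100000 nM in this assay, at which 1 of the 3 values shown sits. The step of an at least 4.2-fold lower number from compound 1 to compound 3 (0.62 log units; beyond the scatter) and the step of an at least 3.9-fold lower number from compound 1 to compound 2 (0.59 log units; beyond the scatter) both pass beyond the scatter, whereas a 1.1-fold lower number from compound 2 to compound 3 (0.03 log units; within the scatter) stays within it.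

Compound 4 `O=C(/C=C/c1ccc2c(c1)B(O)OC2)c1cccc(F)c1` keeps every atom of compound 3 and differs only in where the fluorine sits on the ring attached to the carbonyl: 3-fluorophenyl in place of 2-fluorophenyl on a carbonyl carbon. Within the data shown here, none of the measured steps exchanges one fluorophenyl for another. Among the measured compounds shown here, the two steps that were large both set out from the limit reached by compound 1, and the single step between two real numbers, a 1.1-fold lower number from compound 2 to compound 3 (0.03 log units; within the scatter), lies within the scatter even though it swaps a 4-aminophenyl for a 2-fluorophenyl. The evidence therefore gives no reason to expect a move beyond the scatter in this assay for compound 4.

Compound 4 is expected to show a 1.1-fold higher number from compound 3 to compound 4 (0.03 log units; within the scatter). The estimated value for compound 4 is 25000 nM, with a range from 10000 nM to 65000 nM.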

Compound 4, half-maximal inhibitory concentration: 26700 nM
The estimate for compound 4 lay 1.1-fold (0.03 log units) below the measured number; measured number inside the range.
By their numbers in this assay, from the lowest: compounds 3, 2 and 4 (each within the scatter of the next). At a limit, above all of these: compound 1.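

In this assay, among these compounds, the exchange of 2-fluorophenyl for 3-fluorophenyl on the carbonyl carbon is the first step between two fluorophenyl compounds, and a 1.1-fold higher number from compound 3 to compound 4 (0.05 log units; within the scatter) shows that changing where the fluorine sits on this ring does not carry the number beyond the scatter. The comparison with the 4-aminophenyl compound gives the same picture, a 1.1-fold higher number from compound 2 to compound 4 (0.02 log units; within the scatter), so 3-fluorophenyl now joins 2-fluorophenyl and 4-aminophenyl as a third group at this place whose numbers cannot be told apart. Only the step that sets out from the 4-hydroxyphenyl compound passes beyond the scatter, an at least 3.7-fold lower number from compound 1 to compound 4 (0.57 log units; beyond the scatter), and its size can be read only as a lower bound, as compound 1 stands at a limit and not at a number: the limit of > 100000 nM in this assay, at which 1 of the 4 values shown sits.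

The compounds shown leave open whether this level holds for a plain phenyl, a chlorophenyl or a pyridine ring on the same carbonyl carbon. They also leave open whether the limit belongs to the hydroxy group as such, which a methoxy group or a carboxylic acid in its stead could test.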